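Aryl Amine in Place of Cyclopropyl Amine on the Shared Core

The source may hold more compounds than are shown below. What is called first, only, known or untested is meant among the compounds shown, and "the series" means these compounds.

Compound 1 `O=c1cc(NC2CC2)cc(-c2ccccc2)o1`: > 30 uM
Compound 2 `COc1ccc(Nc2cc(C3CCCCC3)oc(=O)c2)cc1`: 8.32 uM
Compound 3 `CCCCCc1cc(Nc2ccc(OC)cc2)cc(=O)o1`: 10.1 uM

In a functional assay on KB cells (Homo sapiens) for cytotoxicity, read by MTT assay, with a stated time of 72 h (a lower number here means that less compound is needed, a higher number that more compound is needed for the effect), compound 1 gives only a limit, > 30 uM; it stands at the limit of > 30 uM in this assay, at which 1 of the 3 values shown sits. Compound 2 gives 8.32 uM. Compound 3 gives 10.1 uM. For the measured compounds named here, the one measured step, a 1.2-fold higher number from compound 2 to compound 3 (0.08 log units; within the scatter), alters a carbon substituent on the shared core and leaves the nitrogen untouched, so it bears little on the change at hand. Compound 4 `Cc1ccc(Nc2cc(-c3ccccc3)oc(=O)c2)cc1` differs from compound 1 by 4-methylphenyl in place of cyclopropyl on a nitrogen on an aromatic ring. Going by the values given here, no measured step covers this change; compound 2 and compound 3, which each carry an aryl group on that nitrogen, give numbers rather than limits. The expected step is therefore an at least 3.0-fold lower number from compound 1 to compound 4 (0.47 log units; beyond the scatter), down off the limit. Compound 4 is estimated at 10 uM, with a range from 3 uM to 30 uM.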

Compound 4, concentration for half-maximal effect: 0.064 uM
The estimate for compound 4 lay 160-fold (2.19 log units) above the measured number; the measured number lies below the stated range.
By their numbers in this assay, from the lowest: compound 4; then compounds 2 and 3 (each within the scatter of the next). At a limit, above all of these: compound 1.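

In this assay, 4-methylphenyl in place of cyclopropyl on a nitrogen on an aromatic ring gives an at least 460-fold lower number from compound 1 to compound 4 (2.67 log units; beyond the scatter). For the compounds shown here, this is the first step read at that nitrogen, and it shows that a change there can move the number far beyond the scatter, unlike the one earlier step, which was on a carbon. Compound 1 stands at a limit, so this step is only a bound: the limit of > 30 uM in this assay, at which 1 of the 4 values shown sits.

On these data alone, whether the shift belongs to the aromatic ring or to its methyl stays open. So does what a plain phenyl, a benzyl or a 4-chlorophenyl on that nitrogen would give.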